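From 1H-indol-6-yl to 2-methyl-2H-indazol-6-yl

This account rests on a few compounds, and the source may have more. Where it says the series, first, only, none or still open, it means among the compounds named here.

In a functional assay on HepG2 cells (Homo sapiens) for inhibition, read by fluorescence and resazurin assay, with a stated time of 72 h (a lower number here means a stronger inhibitor, a higher number a weaker inhibitor), compound 1 `O=C(Nc1ccccc1)Nc1cccc(Nc2nccc(Nc3ccc4cn[nH]c4c3)n2)c1` gives 8200 nM, compound 2 `O=C(Nc1ccccc1)Nc1cccc(Nc2nccc(Nc3ccc4[nH]ccc4c3)n2)c1` gives 5000 nM and compound 3 `O=C(Nc1ccccc1)Nc1cccc(Nc2nccc(Nc3ccc4cc[nH]c4c3)n2)c1` gives 3200 nM. Two steps place compound 3: a 1.6-fold lower number from compound 2 to compound 3 (0.19 log units; within the scatter), and a 2.6-fold lower number from compound 1 to compound 3 (0.41 log units; beyond the scatter). Compound 4 `Cn1cc2ccc(Nc3ccnc(Nc4cccc(NC(=O)Nc5ccccc5)c4)n3)cc2n1` differs from compound 3 in one place: 2-methyl-2H-indazol-6-yl in place of 1H-indol-6-yl on a nitrogen on an aromatic ring. The second step is the closest guide, as it swaps 1H-indazol-6-yl for 1H-indol-6-yl, and read in reverse it points to a higher number. Going by the values given here, no measured compound carries the methyl group, so this guide is only partial. A modest rise is expected, near the edge of the scatter. The estimated change is a 1.7-fold higher number from compound 3 to compound 4 (0.24 log units; within the scatter). Compound 4 is expected at 5500 nM, with an estimated range of 2300 nM to 13000 nM.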

Compound 4, half-maximal inhibitory concentration in the HepG2 assay: 12000 nM
For compound 4 the middle estimate is 2.2-fold (0.34 log units) below the measured one; the measured number falls inside the stated range.
By their numbers in the HepG2 assay, from the lowest: compounds 3, 2, 1 and 4 (each within the scatter of the next, the first and the last beyond it).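

In the HepG2 assay, compound 4 loses ground against both indoles: a 3.8-fold higher number from compound 3 to compound 4 (0.57 log units; beyond the scatter) and a 2.4-fold higher number from compound 2 to compound 4 (0.38 log units; beyond the scatter). Against the indazole without the methyl group the result differs, with a 1.5-fold higher number from compound 1 to compound 4 (0.17 log units; within the scatter), so these two cannot be told apart here. In a physicochemical assay for lipophilicity, read by HPLC, in phosphate buffer, measured as octanol-water partition, with a stated time of 6 h, at pH 7.4 (a higher number here means a more lipophilic compound, a lower number a more polar compound), compound 3 gives >= 4 as a limit of the assay. In the physicochemical assay compound 4 gives >= 4 as a limit of the assay. In the physicochemical assay the step between compound 3 and compound 4 cannot be read, since both values are limits: the limit of >= 4 in the physicochemical assay, at which 2 of the 2 values shown sit.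

Still open, going by these compounds, is how an ethyl group or a longer chain in place of the methyl group would read in the HepG2 assay, and whether an amine or a carboxylic acid on that chain would shift the number.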